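Adding a Cyano Group to a Biaryl Anilide

The source may report more compounds than this note shows. Statements on the series, on what has been measured and on what is new or still open speak of the compounds shown alone.

Within the data shown here, compound 3 `O=C(CCc1cccc2c1B(O)OC2)Nc1cccc(-c2ccccc2)c1` shows the lowest of the three numbers measured so far in an ADME assay on WI-38 cells (Homo sapiens) for cytotoxicity, read by MTT assay, with a stated time of 72 h (a higher number here means a weaker inhibitor, a lower number a stronger inhibitor), where compound 3 gives 12000 nM. Compound 2 `Cc1ccc(NC(=O)CCc2cccc3c2B(O)OC3)cc1Br` lies nearest, within the scatter, as compound 2 gives 15000 nM. Compound 1 `O=C(CCc1cccc2c1B(O)OC2)Nc1ccc(Br)cc1` lies furthest, beyond the scatter, as compound 1 gives 42000 nM. Compound 4 `N#Cc1ccc(-c2cccc(NC(=O)CCc3cccc4c3B(O)OC4)c2)cc1` differs from compound 3 by a single change: cyano in place of hydrogen on an aromatic carbon. Among the measured compounds shown here, no pair of measured compounds here carries this same change, so nothing measured yet tells its size. In this assay the expected step is no change at the digits printed from compound 3 to compound 4 (within the scatter), a step within the scatter, in no fixed direction. Compound 4 is therefore estimated at 12000 nM, with a range from 5000 nM to 30000 nM.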

Compound 4, half-maximal inhibitory concentration: 12000 nM
The estimate for compound 4 equals the measured number at the digits printed; the measured number falls inside the stated range.
By their numbers in this assay, from the lowest: compounds 3, 4 and 2 (each within the scatter of the next); then compound 1.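

Going from phenyl to 4-cyanophenyl, this assay shows no change at the digits printed from compound 3 to compound 4 (within the scatter), so at this position cyano can replace hydrogen without a step beyond the scatter. Among these compounds, this is the first step between compounds that differ in one place, which the earlier compounds could not provide. Nothing measured here accounts for this result.

As far as these compounds go, whether an amine or a carboxylic acid at this carbon would move the number beyond the scatter stays open. So does whether cyano on another carbon of that ring would leave the number as flat.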